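Dimethoxy core with a 3-chlorophenyl acyl group

This account rests on a few compounds, and the source may have more. Where it says the series, first, only, none or still open, it means among the compounds named here.

Measured compounds:
compound 1, `COc1cc2ncnc(NNC(=S)NC(=O)c3ccccc3OC)c2cc1OC`: 8410 nM
compound 2, `O=C(NC(=S)NNc1ncnc2ccccc12)c1cccc(Cl)c1`: 2920 nM
compound 3, `O=C(NC(=S)NNc1ncnc2ccccc12)c1ccc(C(F)(F)F)cc1`: 22500 nM

All three were read in a functional assay on CNE-2 cells (Homo sapiens) for cytotoxicity, read by MTT assay, with a stated time of 72 h; on this read-out higher numbers stand for weaker inhibition and lower numbers for stronger inhibition. On these numbers compound 1 stands second highest of the three: compound 3 lies above it, and that gap is beyond the scatter, while compound 2 lies below it, again beyond the scatter. For the measured compounds named here, compound 1 and compound 2 differ in two places at once (the core and the acyl aryl group), so no single-change step connects them; their two values alone show that the compound carrying the 3-chlorophenyl group on the plain core gives the lowest number of the set.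

Compound 4, `COc1cc2ncnc(NNC(=S)NC(=O)c3cccc(Cl)c3)c2cc1OC`, has not yet been measured in this assay. It keeps the core of compound 1 and changes only the acyl aryl group: 3-chlorophenyl in place of 2-methoxyphenyl on a carbonyl carbon. This puts onto the dimethoxy core the same 3-chlorophenyl group that compound 2 carries on the plain core.

Going by the values given here, with no single-change step available, the expectation rests on compound 2 giving 2920 nM against compound 1 giving 8410 nM. The step of a 2.1-fold lower number from compound 1 to compound 4 (0.32 log units; beyond the scatter) is expected to be a moderate move to a lower number, beyond the scatter but not large. Compound 4 is estimated at 4000 nM, with a range from 1500 nM to 12000 nM.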

Compound 4, half-maximal inhibitory concentration: 7460 nM
The estimate for compound 4 lay 1.9-fold (0.27 log units) below the measured number; the range from low to high includes it.
By their numbers in this assay, from the lowest: compound 2; then compounds 4 and 1 (each within the scatter of the next); then compound 3.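

In this assay, putting 3-chlorophenyl in place of 2-methoxyphenyl on a carbonyl carbon gives a 1.1-fold lower number from compound 1 to compound 4 (0.05 log units; within the scatter), so on the core of compound 1 the two acyl aryl groups cannot be told apart on this read-out. For the compounds shown here, this is the first reading at this position with the core held fixed, and it shows that the two groups can be exchanged here without a difference beyond the scatter, even though the entering group swaps the methoxy oxygen, counted as a hydrogen-bond acceptor, for a chlorine and sits on the ring under a different name. No measurement offered here explains this outcome, and the step itself gives no account of it.

The compounds shown leave open whether an amine or a carboxylic acid on the acyl aryl group, or a longer chain in place of that aryl group, would move the number on this core beyond the scatter. They also leave open whether the same exchange of 2-methoxyphenyl for 3-chlorophenyl would read the same way on any other core.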